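Swapping Hydroxy for Hydroxymethyl on Two Different Cores

The compounds below may be only part of what the source reports. "The series", "measured", "known", "first", "only" and "open" are said of these compounds alone.

Compound 1 `CC1(C)OC(=O)C2(C(=O)O1)[C@@H](c1ccc(-c3ccc(O)cc3)cc1)CC(=O)C[C@H]2c1ccccc1` and compound 2 `CC1(C)OC(=O)C2(C(=O)O1)[C@@H](c1ccc(-c3ccc(CO)cc3)cc1)CC(=O)C[C@H]2c1ccccc1` share one core and differ at a single spot: hydroxymethyl in place of hydroxy on an aromatic carbon. In a functional assay on HL-60 cells (Homo sapiens) for antiproliferative activity, read by trypan blue exclusion, with a stated time of 48 h (on this read-out higher numbers stand for weaker inhibition and lower numbers for stronger inhibition), compound 1 gives 8000 nM and compound 2 gives 20000 nM, which is a 2.5-fold higher number from compound 1 to compound 2 (0.40 log units; beyond the scatter). Compound 3 `Oc1ccc(-c2cc(O)cc(O)c2)cc1` is built on another core, and the difference between the two cores is not broken down here. In this assay compound 3 reaches only a limit, > 80000 nM. That limit is the limit of > 80000 nM in this assay, at which 1 of the 3 values shown sits. Compound 4 `OCc1ccc(-c2cc(O)cc(O)c2)cc1` is not yet measured and differs from compound 3 by hydroxymethyl in place of hydroxy on an aromatic carbon. This is the same kind of change as from compound 1 to compound 2, though in compound 2 the new group sits para to a large group, while in compound 4 it sits para to a group of 8 heavy atoms. Resting on the step of a 2.5-fold higher number from compound 1 to compound 2 (0.40 log units; beyond the scatter) and on where compound 3 stands, compound 4 is expected to give 120000 nM. The step from compound 3 to compound 4 is estimated at a step that the limit leaves unreadable from compound 3 to compound 4.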

Compound 4, half-maximal inhibitory concentration: > 80000 nM
Compound 4: a limit, no number; the forecaster's own chance of this, stated with the estimate: 80%; the middle value is on the limit's open side.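

No step can be read from compound 3 to compound 4, because both compounds sit at a limit rather than a number: the limit of > 80000 nM in this assay, at which 2 of the 4 values shown sit.

From the compounds shown here alone, whether hydroxymethyl in place of hydroxy changes the number on the core of compound 3 as it does on the core of compound 1 stays open.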